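Swapping the diacid amine for a methyl ester

A few compounds are considered here, and "the series" means these few. Any claim that something is new, unique, unknown or untested is made for them only; others in the source may bear on it.

Compound 1: `COC(=O)c1ccc(CN(CCCc2c(N)nc(N)nc2O)c2cc(F)ccc2[N+](=O)[O-])cc1`, 30000 nM
Compound 2: `Nc1nc(N)c(CCCN(Cc2ccc(NC(CCC(=O)O)C(=O)O)cc2)c2ccc([N+](=O)[O-])c(F)c2F)c(O)n1`, > 100000 nM

In a functional assay on CCRF-CEM cells (Homo sapiens) for cytotoxicity, in the presence of a further agent that is not named here (a lower number here means a stronger inhibitor, a higher number a weaker inhibitor), compound 1 gives 30000 nM. For compound 2 the assay reports only a limit, > 100000 nM, so compound 2 stands at the limit of the values shown (the limit of > 100000 nM in this assay, at which 1 of the 2 values shown sits). Compound 3, `COC(=O)c1ccc(CN(CCCc2c(N)nc(N)nc2O)c2ccc([N+](=O)[O-])c(F)c2F)cc1`, carries a (methoxycarbonyl in place of (1,3-dicarboxypropyl)amino on an aromatic carbon). Going by the values given here, no measured pair differs in one place, so the size of this change is not known from the measured compounds. Since compound 1 also bears the methoxycarbonyl group and gives 30000 nM, compound 3 is expected to come out closer to compound 1 than to compound 2. Compound 3 is estimated at 40000 nM, between 10000 nM and 150000 nM, which means an expected step of an at least 2.5-fold lower number from compound 2 to compound 3 (0.39 log units; beyond the scatter).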

Compound 3, half-maximal inhibitory concentration: 45000 nM
Estimate against measurement, compound 3: 1.1-fold (0.05 log units) below; measured number inside the range.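

In this assay, going by these compounds alone, methoxycarbonyl in place of (1,3-dicarboxypropyl)amino gives an at least 2.2-fold lower number from compound 2 to compound 3 (0.34 log units; beyond the scatter), the first reading of this change at this aromatic carbon. The value for compound 2 is a limit, so the true size of the step stays unknown: the limit of > 100000 nM in this assay, at which 1 of the 3 values shown sits.
The change of aryl group on the amine nitrogen gives a 1.5-fold higher number from compound 1 to compound 3 (0.18 log units; within the scatter), so the two aryl groups cannot be told apart here.

The compounds shown leave open whether the step belongs to the ester itself or to the loss of the diacid amine. A free carboxylic acid or a simple amine at this carbon would separate the two.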